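Solubility at low pH across a pyrimidine series

The source may report more compounds than this note shows. Statements on the series, on what has been measured and on what is new or still open speak of the compounds shown alone.

Measured so far in a physicochemical assay for solubility, with a stated time of 24 h, at pH 3; on this read-out lower numbers stand for lower solubility and higher numbers for higher solubility:
compound 1, `CC(=O)N1CCC(c2nc(NCc3ccccn3)ncc2-c2cc(C)no2)CC1`, 221000 nM
compound 2, `CC(=O)N1CCC(c2nc(NC(C)C)ncc2-c2cc(C)no2)CC1`, 224000 nM

Compound 1 holds the lowest of the two numbers in this assay, and compound 2 sits so close that the two cannot be told apart: the step of a 1.0-fold higher number from compound 1 to compound 2 (0.01 log units; within the scatter) is within the scatter. That step concerns the group on the ring nitrogen-bound amine and leaves the rest of the shared core untouched.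

Compound 3, `Cc1cc(-c2cnc(NCc3ccccn3)nc2-c2ccc(C)s2)on1`, is the next candidate for this assay. It differs from compound 1 in one place: 5-methylthiophen-2-yl in place of 1-acetylpiperidin-4-yl on an aromatic carbon. Going by the values given here, no measured step touches this position; the single step from compound 1 to compound 2 bears on a different part of the molecule and was flat, so it offers no guide to the size or direction of the change here. The expectation therefore rests on little. A lower number than compound 1 is expected for compound 3 in this assay, with a wide range: 30000 nM, between 4000 nM and 200000 nM, corresponding to an expected step of a 7.4-fold lower number from compound 1 to compound 3 (0.87 log units; beyond the scatter).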

Compound 3, solubility: 1000 nM
Compound 3: middle estimate off by 30-fold (1.48 log units), on the high side; measured number below the stated range.
By their numbers in this assay, from the lowest: compound 3; then compounds 1 and 2 (each within the scatter of the next).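

In this assay, the step of a 220-fold lower number from compound 1 to compound 3 (2.34 log units; beyond the scatter) shows that the aromatic carbon next to the ring nitrogen is highly sensitive to the group it carries, in contrast with the flat step a 1.0-fold higher number from compound 1 to compound 2 (0.01 log units; within the scatter) on the amine nitrogen. In this change, 5-methylthiophen-2-yl, a five-membered aromatic ring with 6 heavy atoms, replaces 1-acetylpiperidin-4-yl, a six-membered non-aromatic ring with 9 heavy atoms and 1 double bond outside aromatic rings, while both groups have 0 hydrogen-bond donors, 1 hydrogen-bond acceptor and no net charge, so these counts do not separate them. No measurement available on these compounds accounts for the size of the step.

The compounds shown leave open which part of the exchange carries the step, since ring type, ring size, the sulfur, the acetyl group and the methyl group all change together; an unsubstituted piperidin-4-yl amine, a phenyl ring or an unmethylated thiophene at this carbon would begin to separate these parts. Going by these compounds, it also remains open whether the flat result at the amine nitrogen would hold with 5-methylthiophen-2-yl in place, as an isopropyl amine on that background would show.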